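Piperidin-1-yl in place of pyrrolidin-1-yl on a carbonyl carbon

The source may report more compounds than this note shows. Statements on the series, on what has been measured and on what is new or still open speak of the compounds shown alone.

Measured so far in an ADME assay on MDCKII-LE cells (Canis lupus familiaris) for permeability (a higher number here means that the compound crosses the layer faster, a lower number that the compound crosses the layer more slowly), are:
- compound 1 `CCN(C)C(=O)c1cnc(Oc2cc(C(=O)Nc3cnc(C)cn3)cc3oc(C)cc23)cn1` (24.1 10^-6 cm/s)
- compound 2 `Cc1cnc(NC(=O)c2cc(Oc3cnc(C(=O)N4CCCC4)cn3)c3cc(C)oc3c2)cn1` (15.8 10^-6 cm/s)

Going by the values given here, compound 2 lies within the scatter of compound 1, and no other measured compound stands near it. Compound 3 `Cc1cnc(NC(=O)c2cc(Oc3cnc(C(=O)N4CCCCC4)cn3)c3cc(C)oc3c2)cn1` changes the group on the same carbonyl carbon (piperidin-1-yl in place of pyrrolidin-1-yl on a carbonyl carbon), with piperidin-1-yl in place of pyrrolidin-1-yl. Among the compounds with values here, only one measured step bears on this place (a 1.5-fold lower number from compound 1 to compound 2 (0.18 log units; within the scatter)), and it stayed within the scatter. No change beyond the scatter is therefore expected in this assay and the estimated step (a 1.1-fold lower number from compound 2 to compound 3 (0.02 log units; within the scatter)) rests on that one comparison. Compound 3 is estimated at 15 10^-6 cm/s within an expected range from 8 10^-6 cm/s to 28 10^-6 cm/s in this measurement.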

Compound 3, apparent permeability: 13.3 10^-6 cm/s
Compound 3: middle estimate off by 1.1-fold (0.05 log units), on the high side; low and high end bracket the measured number.
By their numbers in this assay, from the lowest: compounds 3, 2 and 1 (each within the scatter of the next).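

In this assay, piperidin-1-yl in place of pyrrolidin-1-yl gives a 1.2-fold lower number from compound 2 to compound 3 (0.07 log units; within the scatter) and piperidin-1-yl in place of ethyl(methyl)amino gives a 1.8-fold lower number from compound 1 to compound 3 (0.26 log units; within the scatter). Even the widest of the three pairs therefore stays within the scatter, so on this carbonyl carbon the five-membered ring, the six-membered ring and the open ethyl(methyl)amino group are not told apart. No measurement offers an explanation for this. On these data alone, whether a ring with a second hetero atom, such as morpholin-4-yl or piperazin-1-yl, would give a step beyond the scatter remains open.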